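Swapping bromo for cyano on the sulfonyl ring

The source may report more compounds than this note shows. Statements on the series, on what has been measured and on what is new or still open speak of the compounds shown alone.

Measured compounds:
- compound 1, `O=C1/C(=C/c2ccccc2F)CN(S(=O)(=O)c2ccc(Br)cc2)C/C1=C\c1ccccc1F`: 5200 nM
- compound 2, `N#Cc1ccc(S(=O)(=O)N2C/C(=C\c3ccccc3F)C(=O)/C(=C/c3ccccc3F)C2)cc1`: 14600 nM
- compound 3, `O=C1/C(=C/c2cccc(F)c2)CN(S(=O)(=O)c2ccc(Br)cc2)C/C1=C\c1cccc(F)c1`: 11700 nM

In a functional assay on SMMC-7721 cells (Homo sapiens) for cytotoxicity, read by MTT assay, with a stated time of 24 h (on this read-out higher numbers stand for weaker inhibition and lower numbers for stronger inhibition), compound 1 gives 5200 nM. The change cyano in place of bromo on an aromatic carbon made a step of a 2.8-fold higher number from compound 1 to compound 2 (0.45 log units; beyond the scatter). Compound 3 carries the same atoms as compound 1, joined differently; the difference between the two cores is not broken down here. In this assay compound 3 gives 11700 nM, and compound 2 gives 14600 nM, within the scatter of each other.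

Compound 4, `N#Cc1ccc(S(=O)(=O)N2C/C(=C\c3cccc(F)c3)C(=O)/C(=C/c3cccc(F)c3)C2)cc1`, is not yet measured. Its change from compound 3, (cyano in place of bromo on an aromatic carbon), is the same as that from compound 1 to compound 2, at the same place. Going by the values given here, the only guide is that earlier step, so the expectation for compound 4 is a step of about a 2.4-fold higher number from compound 3 to compound 4 (0.38 log units; beyond the scatter) from compound 3, because the step of a 2.8-fold higher number from compound 1 to compound 2 (0.45 log units; beyond the scatter) went the same way. This rests on a single measured pair and the core differs, so the range is kept wide. Compound 4 is estimated at 28000 nM, expected between 12000 nM and 65000 nM.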

Compound 4, half-maximal inhibitory concentration: 4500 nM
Compound 4: the middle estimate sits 6.2-fold (0.79 log units) above what was measured, and the stated range ends above it.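

In this assay, putting cyano in place of bromo on the sulfonyl ring gave a 2.6-fold lower number from compound 3 to compound 4 (0.41 log units; beyond the scatter), so on this core the change moved the number the opposite way from the earlier pair. Set side by side, the two steps disagree by more than ordinary scatter can explain: the same change on two cores in this assay, a 2.8-fold higher number (0.45 log units; beyond the scatter) from compound 1 to compound 2 and a 2.6-fold lower number (0.41 log units; beyond the scatter) from compound 3 to compound 4, 7.3-fold (0.86 log units) apart, beyond the scatter of two such steps. Going by these compounds alone, this shows that the effect of this swap measured on one core could not be carried over to the other, although the two cores carry the same atoms joined differently; with only two pairs in one assay, it does not show why the steps differ, nor which core's behaviour would be the more typical.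

The compounds shown leave open how an amine or a carboxylic acid in place of bromo would behave on each of the two cores. They also leave open whether a chloro group, swapped in the same way, would show the same reversal between the cores.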